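Benzylsulfonamide amide series: methoxy for chloro on compound 2

The source may hold more compounds than are shown below. What is called first, only, known or untested is meant among the compounds shown, and "the series" means these compounds.

Measured so far in an assay on MDA-MB-231 cells for binding affinity to C-X-C chemokine receptor type 4 (Homo sapiens), read by immunofluorescence and microscopy, with stated times of 10 min and 30 min; a lower number here means that less compound is needed, a higher number that more compound is needed for the effect:
compound 1 `Cc1ccc(S(=O)(=O)NCc2ccc(CNC(=O)c3cccc(Cl)c3)cc2)cc1` gives 100 nM
compound 2 `O=C(NCc1ccc(CNS(=O)(=O)c2ccccc2)cc1)c1cccc(Cl)c1` gives 1000 nM
compound 3 `Cc1ccc(S(=O)(=O)NCc2ccc(CNC(=O)c3ccccc3Cl)cc2)cc1` gives 10 nM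

Compound 2 has the highest number of the three; a 10-fold higher number from compound 1 to compound 2 (1.00 log units; beyond the scatter) separates it from compound 1, and compound 3 lies further below it still. Compound 4 `COc1cccc(C(=O)NCc2ccc(CNS(=O)(=O)c3ccccc3)cc2)c1` differs from compound 2 by methoxy in place of chloro on an aromatic carbon.

Among the compounds with values here, no measured step exchanges the chloro itself. a 10-fold higher number from compound 1 to compound 2 (1.00 log units; beyond the scatter) concerns the methyl on the sulfonyl ring, and a 10-fold lower number from compound 1 to compound 3 (1.00 log units; beyond the scatter) moves the chloro to another position rather than replacing it; both steps were modest. A modest step in this assay is therefore expected for compound 4, with no clear direction from these data. The estimate for compound 4 is 1500 nM, range 400 nM to 6000 nM, which means an expected step of a 1.5-fold higher number from compound 2 to compound 4 (0.18 log units; within the scatter).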

Compound 4, effective concentration (reported as EC, without a stated level of effect): > 1000 nM
Compound 4 gave a limit, no number; the forecaster's own chance of this, stated with the estimate: 10%; the middle value lies beyond the limit too.
By their numbers in this assay, from the lowest: compound 3; then compound 1; then compound 2.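

Compound 4 carries a limit, not a number: the limit of > 1000 nM in this assay, at which 1 of the 4 values shown sits.

Within the data shown here, this is the first exchange of the chloro itself on an aromatic carbon of this series, and it gives a number no lower from compound 2 to compound 4 (the limit leaves the size open). On this core, 3-methoxyphenyl therefore brings no gain over 3-chlorophenyl in this assay.

How far compound 4 lies from compound 2 cannot be read. Going by these compounds, whether an amine or a carboxylic acid in the same place would give a lower number stays open.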